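The compounds below may be only part of what the source reports. "The series", "measured", "known", "first", "only" and "open" are said of these compounds alone.

Measured in a functional assay on HCT-116 cells (Homo sapiens) for antiproliferative activity; on this read-out higher numbers stand for weaker inhibition and lower numbers for stronger inhibition:
- compound 1 `CCCCO/N=C/c1c(N)ncnc1Oc1ccc2[nH]c(C)cc2c1F` gives 1000 nM
- compound 2 `Cc1cc2c(F)c(Oc3ncnc(N)c3/C=N/OCCO)ccc2[nH]1` gives 323 nM

Compound 1 has the higher of the two numbers and is therefore the weaker inhibitor of the pair. Compound 3 `Cc1cc2c(F)c(Oc3ncnc(N)c3/C=N/O)ccc2[nH]1` has not yet been measured. Its difference from compound 1 is hydrogen in place of butyl on an oxygen, the oxygen whose other neighbour is a double-bonded nitrogen (hydrogen in place of butyl on an oxygen). Among the compounds with values here, the one measured step that bears on this is modest: a 3.1-fold lower number from compound 1 to compound 2 (0.49 log units; beyond the scatter) with hydroxy in place of ethyl on the same chain. Within the data shown here, no measured compound shows the whole chain gone, so that step is only a rough guide to direction and size. A similar step a 3.3-fold lower number from compound 1 to compound 3 (0.52 log units; beyond the scatter) is expected in this assay with considerable uncertainty. The expected value for compound 3 is 300 nM with an estimated range (80 nM to 1000 nM).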

Compound 3, half-maximal inhibitory concentration: 1140 nM
Estimate against measurement, compound 3: 3.8-fold (0.58 log units) below; measured number outside the range, above it.
By their numbers in this assay, from the lowest: compound 2; then compounds 1 and 3 (each within the scatter of the next).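

In this assay, hydrogen in place of butyl on the oxygen whose other neighbour is a double-bonded nitrogen gives a 1.1-fold higher number from compound 1 to compound 3 (0.06 log units; within the scatter), so the butoxy and hydroxy forms cannot be told apart on this read-out. Hydrogen in place of 2-hydroxyethyl on the same oxygen gives a 3.5-fold higher number from compound 2 to compound 3 (0.55 log units; beyond the scatter), so the number at this position depends on what the chain carries and not simply on whether a chain is present: of the three groups, only 2-hydroxyethyl stands apart. No evidence on the cause of this pattern is at hand.

Going by these compounds, it remains open whether the lower number of compound 2 belongs to the hydroxy on the chain or to the length of that chain. A 2-methoxyethyl, 2-aminoethyl or 3-hydroxypropyl chain on the same oxygen would help to separate these two readings.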